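The compounds below may be only part of what the source reports. "The series", "measured", "known", "first", "only" and "open" are said of these compounds alone.

In a functional assay (Cavia porcellus) with sulfonylurea receptors; K-ATP channels (Homo sapiens) as the target (on this read-out lower numbers stand for stronger inhibition and higher numbers for weaker inhibition), compound 1 `CC(O)(C(=O)Nc1ccc(S(=O)(=O)c2ccccc2Cl)cc1)C(F)(F)F` gives 2300 nM. Compound 2 `CC(O)(C(=O)Nc1ccc(C(=O)c2ccccc2F)cc1)C(F)(F)F` gives 2300 nM in this assay, and compound 3 `CC(O)(C(=O)Nc1ccc(C(=O)c2cccc(F)c2)cc1)C(F)(F)F` gives 2600 nM. The number for compound 3 sits within the usual scatter of both compound 1 and compound 2, so no ordering among the three can be claimed. Compound 4 `CC(O)(C(=O)Nc1ccc(C(=O)c2ccc(F)cc2)cc1)C(F)(F)F` differs from compound 3 by 4-fluorophenyl in place of 3-fluorophenyl on a carbonyl carbon. Among the measured compounds shown here, the only measured step that bears on such a relocation of the fluorine, a 1.1-fold higher number from compound 2 to compound 3 (0.05 log units; within the scatter), stayed within the scatter, so no change beyond the scatter is expected in this assay in either direction. Compound 4 is therefore expected to give about 2600 nM, with a range from 1300 nM to 5200 nM. The estimated step this implies is no change at the digits printed from compound 3 to compound 4 (within the scatter).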

Compound 4, half-maximal inhibitory concentration: 14000 nM
For compound 4 the middle estimate is 5.4-fold (0.73 log units) below the measured one; measured number above the stated range.
By their numbers in this assay, from the lowest: compounds 1, 2 and 3 (each within the scatter of the next); then compound 4.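

In this assay the place of the fluorine on the phenyl does matter, with a 5.4-fold higher number from compound 3 to compound 4 (0.73 log units; beyond the scatter) and a 6.1-fold higher number from compound 2 to compound 4 (0.78 log units; beyond the scatter) while 2-fluorophenyl and 3-fluorophenyl stay within the scatter of each other. Of the three fluorophenyl groups on this carbonyl carbon, only 4-fluorophenyl stands apart, toward weaker inhibition, although the atoms are the same. Nothing available explains this result. Open, going by these compounds, is whether chlorine, a methoxy group or an amine in place of the fluorine of 4-fluorophenyl would give a similarly high number, and how plain phenyl would compare.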